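A few compounds are considered here, and "the series" means these few. Any claim that something is new, unique, unknown or untested is made for them only; others in the source may bear on it.

Measured compounds:
compound 1, `CCn1nc(C#Cc2cc(C(=O)Nc3cccc(C(F)(F)F)c3)ccc2C)c2c(N)ncnc21`: > 10000 nM
compound 2, `Cc1ccc(C(=O)Nc2cccc(C(F)(F)F)c2)cc1C#Cc1nn(CC2CCN(C)C2)c2ncnc(N)c12`: 3500 nM

In an ADME assay on HepG2 cells (Homo sapiens) for antiproliferative activity, read by MTT assay, with a stated time of 72 h (a higher number here means a weaker inhibitor, a lower number a stronger inhibitor), compound 2 gives 3500 nM, the only plain number shown. For compound 1 the assay reports only a limit, > 10000 nM (the limit of > 10000 nM in this assay, at which 1 of the 2 values shown sits). Among the measured compounds shown here, the one measured step is an at least 2.8-fold lower number from compound 1 to compound 2 (0.45 log units; beyond the scatter). Compound 3, `Cc1ccc(C(=O)Nc2cccc(C(F)(F)F)c2)cc1C#Cc1nn(CC2CCN(C)CC2)c2ncnc(N)c12`, differs from compound 2 by 1-methylpiperidin-4-yl in place of 1-methylpyrrolidin-3-yl on a saturated chain carbon bound to an aromatic nitrogen. That measured step bears only loosely on it, since here one saturated ring is exchanged for a closely related one rather than introduced; no step beyond the scatter is expected, a 1.2-fold lower number from compound 2 to compound 3 (0.07 log units; within the scatter). Compound 3 is therefore estimated at 3000 nM, with a range from 1200 nM to 8000 nM.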

Compound 3, half-maximal inhibitory concentration: 3100 nM
Beside the measured number, compound 3's estimate is 1.0-fold (0.01 log units) below it; the range from low to high includes it.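

In this assay the larger ring, 1-methylpiperidin-4-yl, gives a 1.1-fold lower number from compound 2 to compound 3 (0.05 log units; within the scatter), so at this place the two rings cannot be told apart. The gain over the plain methyl also recurs with this second ring, as an at least 3.2-fold lower number from compound 1 to compound 3 (0.50 log units; beyond the scatter) shows. Compound 1 stands at a limit of the assay, not at a number: the limit of > 10000 nM in this assay, at which 1 of the 3 values shown sits.

Open, on these data alone, is whether the methyl on the ring nitrogen matters, since both rings carry it. Also open, as far as these compounds go, is how a morpholine ring or an open-chain dimethylamino group would behave at this place.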